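Fluoro to methyl on the benzyl group of compound 2

The source may report more compounds than this note shows. Statements on the series, on what has been measured and on what is new or still open speak of the compounds shown alone.

In a functional assay on DU-145 cells (Homo sapiens) for inhibition, read by trypan blue exclusion, with a stated time of 96 h (on this read-out lower numbers stand for stronger inhibition of growth and higher numbers for weaker inhibition of growth), compound 1 `CN(C)c1ccc(/C=C(/Sc2ccc(Br)cc2)C(=O)c2ccc(Cl)cc2)cc1` gives > 100000 nM, which is a limit of the assay and not a number. Going by the values given here, compound 2 `CN(C)c1ccc(/C=C(/SCc2ccc(F)cc2)C(=O)c2ccc(Cl)cc2)cc1` gives 50000 nM, the only true number so far. The reading on the sulfur substituent is bounded by the limit of > 100000 nM in this assay, at which 1 of the 2 values shown sits.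

Compound 3 `Cc1ccc(CS/C(=C/c2ccc(N(C)C)cc2)C(=O)c2ccc(Cl)cc2)cc1` differs from compound 2 by methyl in place of fluoro on an aromatic carbon, para to a large group. Among the compounds with values here, the one measured step, an at least 2.0-fold lower number from compound 1 to compound 2 (0.30 log units; that floor lies within the scatter), is a different change, and its floor lies within the scatter. It therefore gives no ground for expecting a shift here. The expected step, no change at the digits printed from compound 2 to compound 3 (within the scatter), stays within the scatter in this assay, with no direction favoured. For compound 3 the estimated value is 50000 nM, with an expected range of 20000 nM to 100000 nM.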

Compound 3, concentration for 50% growth inhibition: > 100000 nM
Compound 3: a limit, no number; the forecaster's own chance of this, stated with the estimate: 25%; middle value at least 2.0-fold (0.30 log units) away from the limit.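

Methyl in place of fluoro on an aromatic carbon, para to a large group, reads in this assay as an at least 2.0-fold higher number from compound 2 to compound 3 (0.30 log units; that floor lies within the scatter). Going by these compounds alone, this is the first reading at this position, and it is only a floor: the true step could still lie within the scatter or well beyond it. Compound 2 remains the only compound with a true number, and the step from compound 1 to compound 3 cannot be read, so the series still rests mainly on a limit: the limit of > 100000 nM in this assay, at which 2 of the 3 values shown sit.

The compounds shown leave open how chloro, methoxy or an amine would read at this position. They also leave open whether the number for compound 2 depends on fluoro specifically or would also appear with other groups there.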